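Cyclohexenyl Ester in Place of a Branched Alkenyl Chain

The source may report more compounds than this note shows. Statements on the series, on what has been measured and on what is new or still open speak of the compounds shown alone.

Measured compounds:
compound 1 `CCOC(=O)C1=C(C)NC(C(OCC)OCC)=C(C(=O)OCC)C1c1cccc([N+](=O)[O-])c1` with 615 nM
compound 2 `C=C(C)CCOC(=O)C1=C(C)NC(C)=C(C(=O)OC)C1c1cccc([N+](=O)[O-])c1` with 47 nM

In a functional assay on HEK293 cells for antagonist activity at Voltage-dependent L-type calcium channel subunit alpha-1D (Rattus norvegicus), read by FLIPR (on this read-out higher numbers stand for weaker inhibition and lower numbers for stronger inhibition), compound 1 gives 615 nM, while compound 2 gives 47 nM. Compound 2 thus holds the lower of the two numbers, and compound 1 stands beyond the scatter above it.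

Compound 3 `COC(=O)C1=C(C)NC(C)=C(C(=O)OC2C=CCCC2)C1c1cccc([N+](=O)[O-])c1` has not yet been measured. It differs from compound 2 in one place: cyclohex-2-en-1-yl in place of 3-methylbut-3-en-1-yl on an oxygen next to a carbonyl group. Among the measured compounds shown here, no pair of measured compounds shows this change, so no measured step can guide the expectation; the two groups are alike in size and both carry one double bond outside aromatic rings. A step no larger than the scatter is expected, in either direction.

Compound 3 is therefore expected to give about 45 nM in this assay, with a range from 12 nM to 160 nM. The step of a 1.0-fold lower number from compound 2 to compound 3 (0.02 log units; within the scatter) is expected to stay within the scatter.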

Compound 3, half-maximal inhibitory concentration: 10 nM
For compound 3 the middle estimate is 4.5-fold (0.65 log units) above the measured one; the measured number lies below the stated range.
By their numbers in this assay, from the lowest: compound 3; then compound 2; then compound 1.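

Among the compounds shown here, this is the first measured change at this place, on an oxygen next to a carbonyl group, and in this assay cyclohex-2-en-1-yl in place of 3-methylbut-3-en-1-yl gives a 4.7-fold lower number from compound 2 to compound 3 (0.67 log units; beyond the scatter). The place therefore responds to the choice of group, even between two groups that each carry 1 double bond outside aromatic rings and have no hydrogen-bond donors or acceptors; the ring of cyclohex-2-en-1-yl is the difference the count shows, and here it goes with stronger inhibition. No measurement at hand bears on why this step occurs.

From the compounds shown here alone, whether the ring alone or the ring together with its double bond goes with the stronger inhibition remains open, and a saturated cyclohexyl group at this place would separate the two. Going by these compounds, how far the trend extends is also open, as cyclopentenyl or a longer alkenyl chain could show whether ring size or chain length matters here.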